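Cytotoxicity notes: acyl extension of compound 2

A few compounds are considered here, and "the series" means these few. Any claim that something is new, unique, unknown or untested is made for them only; others in the source may bear on it.

Compound 1 `CC(=O)OCC(=O)[C@H](C[C@@H]1CCNC1=O)NC(=O)[C@H](CC(C)C)NC(=O)OCc1cccc(Cl)c1` is tested in a toxicity assay on Vero C1008 cells (Chlorocebus sabaeus) for cytotoxicity, read by luminescence and CellTiter-Glo, with a stated time of 24 h; a lower number here means that less compound is tolerated, a higher number that more compound is tolerated; for compound 1 the value > 200000 nM is a limit of the assay and not a number. Compound 2 `COc1cccc2[nH]c(C(=O)N[C@@H](CC(C)C)C(=O)N[C@@H](C[C@@H]3CCCNC3=O)C(=O)CO)cc12` gives > 200000 nM in this assay, again a limit. Both values sit at the limit of > 200000 nM in this assay, at which 2 of the 2 values shown sit, so compound 2 stands at the edge of what the assay resolves. Compound 3 `COc1cccc2[nH]c(C(=O)N[C@@H](CC(C)C)C(=O)N[C@@H](C[C@@H]3CCCNC3=O)C(=O)COC(=O)C(C)(C)C(F)(F)F)cc12` differs from compound 2 by a group of 9 heavy atoms (5 carbon, 1 oxygen, 3 fluorine; no ring) in place of a hydrogen atom, on an oxygen on a saturated carbon. No step beyond the scatter is expected in this assay. Compound 3 is expected at 200000 nM, within 80000 nM to 400000 nM. The step of a number no higher from compound 2 to compound 3 (the limit leaves the size open) is expected to stay within the scatter.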

Compound 3, half-maximal cytotoxic concentration: > 200000 nM
Compound 3 was reported as a limit (the forecaster's own chance of this, stated with the estimate: 75%); the middle value sits exactly at the limit.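

Among these compounds, compound 2 and compound 3 both stand as limits in this assay and not as numbers, so no step between them can be read. The compounds shown leave open where the half-maximal cytotoxic concentration of any of them truly lies.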